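The source may hold more compounds than are shown below. What is called first, only, known or untested is meant among the compounds shown, and "the series" means these compounds.

Measured compounds in a functional assay on HeLa cells (Homo sapiens) for antiproliferative activity, read by CCK-8 assay, with a stated time of 72 h, tested at 2 uM; a higher number here means a stronger effect of the compound at the concentration tested, a lower number a weaker effect:

compound 1, `CN(C(=S)SCc1ccc(C(=O)Nc2ccccc2N)cc1)c1cccnc1`: compound 1 gives 16%
compound 2, `N#Cc1ccc(N2CCN(C(=S)SCc3ccc(C(=O)Nc4ccccc4N)cc3)CC2)cc1`: compound 2 gives 71.6%
compound 3, `Nc1ccccc1NC(=O)c1ccc(CSC(=S)N2CCc3ccc([N+](=O)[O-])cc32)cc1`: compound 3 gives 45.7%

Compound 2 stands highest of the three numbers in this assay; its nearest neighbour is compound 3, whose number lies lower by a gap beyond the scatter, and compound 1 lies further below, also beyond the scatter. All three share the same core and differ only in the group attached to the thiocarbamate nitrogen.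

Compound 4, `Nc1ccccc1NC(=O)c1ccc(CSC(=S)N2CCN(Cc3ccccc3)CC2)cc1`, is not yet measured. It differs from compound 2 in one place: benzyl in place of 4-cyanophenyl on an amine nitrogen in a ring. The nitrile-bearing ring is thus exchanged for a plain benzyl on the amine nitrogen of the six-membered non-aromatic ring with 2 nitrogen.

Among the measured compounds shown here, no pair among the measured compounds isolates this exchange, so its effect on this assay is unknown from the data. The wide spread from compound 1 through compound 3 to compound 2 shows that the group on this nitrogen moves the number strongly. A moderate step downward is expected, a number 21.6 percentage points lower from compound 2 to compound 4 (beyond the scatter), though a change within the scatter cannot be excluded. For compound 4 the estimate in this assay is 50%, with a range from 22% to 78%.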

Compound 4, a percentage reported as inhibition, at one concentration (the size of the read-out at that concentration, not a potency): 20.6%
Compound 4: the middle estimate sits 29.4 percentage points above what was measured; the measured number lies below the stated range.
By their numbers in this assay, from the lowest: compounds 1 and 4 (each within the scatter of the next); then compound 3; then compound 2.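

Among the compounds shown here, as the first pair that differs in one place, compounds 2 and 4 show in this assay that, with the six-membered non-aromatic ring with 2 nitrogen kept, exchanging only the group on its amine nitrogen still gives a large step: a number 51 percentage points lower from compound 2 to compound 4 (beyond the scatter). Both groups carry one six-membered aromatic ring of carbon only, so the presence of such a ring on this nitrogen does not by itself preserve the higher number, as compound 4 gives 20.6%. No measurement available here accounts for the step.

The compounds shown leave open whether the step follows the loss of the nitrile, the added methylene link, or both. A plain phenyl and a 4-cyanobenzyl on this nitrogen would separate the two parts of the exchange.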